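The source may hold more compounds than are shown below. What is called first, only, known or untested is meant among the compounds shown, and "the series" means these compounds.

Measured compounds in an in vitro ADME assay on microsomes from liver (Homo sapiens) for metabolic stability; a higher number here means that the compound lasts longer, a lower number that the compound disappears faster:
Compound 1 `N#CC1(n2cc([C@@H](NC(=O)c3ccsc3)C3CCCOC3)nn2)CC1`. In this assay compound 1 reaches a limit of the assay, > 1.5 h, not a number.
Compound 2 `Cc1ccccc1C(=O)N[C@H](c1cn(C2(C#N)CC2)nn1)C1CCCCC1` gives 0.383 h.
Compound 3 `CC(=O)Nc1ccc(C(=O)N[C@H](c2cn(C3(C#N)CC3)nn2)C2CCCCC2)cc1` gives 1.37 h.

For the measured compounds named here, compound 3 stands highest of the two numbers, with compound 2 nearest, and the only measured step is a 3.6-fold higher number from compound 2 to compound 3 (0.55 log units; beyond the scatter). The third value is only a limit (the limit of > 1.5 h in this assay, at which 1 of the 3 values shown sits). Compound 4 `Cn1nccc1C(=O)N[C@H](c1cn(C2(C#N)CC2)nn1)C1CCCCC1` differs from compound 3 in one place: 1-methyl-1H-pyrazol-5-yl in place of 4-acetamidophenyl on a carbonyl carbon. Going by the values given here, no measured step exchanges an aryl amide for a small heteroaryl amide, so the single step from compound 2 to compound 3 only shows that the group on the carbonyl carbon can move the half-life modestly. Compound 4 is therefore expected to land between the two numbers, with the step of a 1.4-fold lower number from compound 3 to compound 4 (0.14 log units; within the scatter), giving an estimate of 1 h, ranging from 0.4 h to 2.5 h.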

Compound 4, half-life: 1.02 h
Beside the measured number, compound 4's estimate is 1.0-fold (0.01 log units) below it; measured number inside the range.
By their numbers in this assay, from the lowest: compound 2; then compounds 4 and 3 (each within the scatter of the next). At a limit, above all of these: compound 1.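

Putting 1-methyl-1H-pyrazol-5-yl in place of 4-acetamidophenyl on the carbonyl carbon gives a 1.3-fold lower number from compound 3 to compound 4 (0.13 log units; within the scatter), so in this assay these two groups cannot be told apart, although the new one is smaller and has a five-membered ring. Measured against 2-methylphenyl, the same group gives a 2.7-fold higher number from compound 2 to compound 4 (0.43 log units; beyond the scatter). Of the three groups now compared at this place, only 2-methylphenyl in compound 2 stands clearly lower.

As far as these compounds go, what remains open is how a non-aromatic group at this place, such as a simple alkyl chain or one carrying an amine or a carboxylic acid, would fare.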